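A few compounds are considered here, and "the series" means these few. Any claim that something is new, unique, unknown or untested is made for them only; others in the source may bear on it.

Measured so far:
- compound 1 `CC(C)[C@H](NC(=O)CN(c1nc(Cl)nc2[nH]cnc12)C1CC1)C(=O)OCc1ccccc1` — 27.3%
- compound 2 `N=C(N)NCCC[C@H](NC(=O)CN(c1nc(Cl)nc2[nH]cnc12)C1CC1)C(=O)OCc1ccccc1` — 10.2%

In a functional assay on the whole organism (Tail, strain ICR) with Mus musculus as the target, in the tail flick test, with a stated time of 120 min, at a dose of 25 umol/kg by the oral route (a higher number here means a stronger effect of the compound at the dose given, a lower number a weaker effect), compound 1 stands highest of the two numbers; its nearest neighbour is compound 2, with a number 17.1 percentage points lower from compound 1 to compound 2 (beyond the scatter). Compound 3 `CC(C)[C@H](NC(=O)CN(c1nc(Cl)nc2[nH]cnc12)C1CC1)C(=O)O` has not yet been measured. It differs from compound 1 by hydrogen in place of benzyl on an oxygen next to a carbonyl group. Among the compounds with values here, the one measured step changed a different part of the molecule, the saturated chain carbon, and leaves the oxygen untouched, so no measured step bears on this change, and the direction and size of the step in this assay are open. Compound 3 is therefore expected to give roughly 17%, between 0% and 38%, which would mean an estimated a number 10.3 percentage points lower from compound 1 to compound 3 (beyond the scatter).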

Compound 3, a percentage reported as activity, at one dose (the size of the read-out at that dose, not a potency): 17.1%
Estimate against measurement, compound 3: 0.1 percentage points below; the range from low to high includes it.
By their numbers in this assay, from the lowest: compounds 2 and 3 (each within the scatter of the next); then compound 1.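

In this assay, this first change at the oxygen next to a carbonyl group, benzyloxycarbonyl to carboxy, gives a number 10.2 percentage points lower from compound 1 to compound 3 (beyond the scatter), so the benzyl group cannot be removed here without a modest loss at this dose. The loss is only partial, as compound 3 still gives 17.1% in this assay. No supporting measurement bears on why the number falls. From the compounds shown here alone, whether a methyl or ethyl ester on this oxygen, or an amide in place of the ester, would stay nearer compound 1 remains open. So does whether the same change would have a similar effect on the guanidine-bearing chain of compound 2.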